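Compound 3 and a Change on the Aromatic Ring

The source may report more compounds than this note shows. Statements on the series, on what has been measured and on what is new or still open speak of the compounds shown alone.

In a functional assay on CaEs17 cells (Homo sapiens) for cytotoxicity, read by MTT assay, with a stated time of 72 h (a lower number here means a stronger inhibitor, a higher number a weaker inhibitor), the measured compounds gave
- compound 1 `C=C1C(=O)[C@@]23C(=O)OC[C@]4(C(=O)CCC(C)(C)[C@H]4C=O)[C@@H]2CC[C@@H]1[C@H]3OC(C)=O` with 1350 nM
- compound 2 `C=C1C(=O)[C@@]23C(=O)OC[C@]4(C(=O)CCC(C)(C)[C@H]4C=O)[C@@H]2CC[C@@H]1[C@H]3OC(=O)c1ccc(OC)cc1` with 2980 nM

Compound 2 holds the higher of these two numbers and is therefore the weaker inhibitor here. Compound 3 `C=C1C(=O)[C@@]23C(=O)OC[C@]4(C(=O)CCC(C)(C)[C@H]4C=O)[C@@H]2CC[C@@H]1[C@H]3OC(=O)c1ccc([N+](=O)[O-])cc1` has not yet been measured. It departs from compound 2 at one place, with nitro in place of methoxy on an aromatic carbon and so 4-nitrophenyl replaces 4-methoxyphenyl.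

Among the compounds with values here, only one measured step bears on this, and only loosely. That step is a 2.2-fold higher number from compound 1 to compound 2 (0.34 log units; beyond the scatter) and it put 4-methoxyphenyl in place of methyl on a carbonyl carbon. Within the data shown here, no measured pair shows a change on the aromatic ring itself. Given that modest step, no change beyond the scatter is expected in this assay and the direction remains open. The expected step is a 1.2-fold lower number from compound 2 to compound 3 (0.09 log units; within the scatter) for now. Compound 3 is estimated at 2400 nM with an expected range from 1000 nM to 5500 nM in this assay.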

Compound 3, half-maximal inhibitory concentration: 2680 nM
The estimate for compound 3 lay 1.1-fold (0.05 log units) below the measured number; the range from low to high includes it.
By their numbers in this assay, from the lowest: compounds 1, 3 and 2 (each within the scatter of the next, the first and the last beyond it).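

In this assay, within the data shown here, the only measured change on the aromatic ring itself, nitro in place of methoxy, gives a 1.1-fold lower number from compound 2 to compound 3 (0.05 log units; within the scatter) and so does not separate the two groups. Compared with methyl on the carbonyl carbon, 4-nitrophenyl gives a 2.0-fold higher number from compound 1 to compound 3 (0.30 log units; within the scatter) and stays within the scatter, whereas 4-methoxyphenyl gave a 2.2-fold higher number from compound 1 to compound 2 (0.34 log units; beyond the scatter) and lay just beyond it, so the step away from methyl is not clearly tied to one ring substituent, and the two ring-bearing compounds remain close to each other. Nothing available explains these numbers.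

From the compounds shown here alone, it remains open whether an amine or a carboxylic acid on the same aromatic carbon would shift the number beyond the scatter. A longer chain in place of methyl on the carbonyl carbon is also untested among the compounds shown here.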